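Vero cytotoxicity notes on compounds 1 to 3

This account rests on a few compounds, and the source may have more. Where it says the series, first, only, none or still open, it means among the compounds named here.

Measured compounds:
compound 1 `CCCOCC(=O)Nc1cc2nc(C3CCCCC3)[nH]c2cc1N(CC)CC`: > 100 ug/mL
compound 2 `CCN(CC)c1cc2[nH]c(C3CCCCC3)nc2cc1NC(=O)c1cccc(Br)c1`: > 100 ug/mL

In an ADME assay on Vero cells (Chlorocebus sabaeus) for cytotoxicity, read by resazurin assay, with a stated time of 3 days (a lower number here means a stronger inhibitor, a higher number a weaker inhibitor), compound 1 returns a limit, > 100 ug/mL, and no number. Compound 2 likewise returns only a limit of > 100 ug/mL in this assay. The step that the two limits leave unreadable from compound 1 to compound 2 is therefore not readable in either direction. Compound 2 stands, on the numbers shown, at the top of the measured window: both values shown sit at the limit of > 100 ug/mL in this assay, at which 2 of the 2 values shown sit.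

Compound 3 `CCN(CC)c1cc2[nH]c(C3CCCCC3)nc2cc1NC(=O)c1ccc(F)cc1F` differs from compound 2 by 2,4-difluorophenyl in place of 3-bromophenyl on a carbonyl carbon. Among the measured compounds shown here, the one measured step, a step that the two limits leave unreadable from compound 1 to compound 2, touches the same carbonyl position but gives no size, so no measured step supplies a direction or magnitude for this change. Given that compound 1 and compound 2 both sit at the limit of > 100 ug/mL in this assay, at which 2 of the 2 values shown sit, compound 3 is expected to sit at the limit as well, and the step of a number no higher from compound 2 to compound 3 (the limit leaves the size open) is expected to be none beyond the scatter. Compound 3 is estimated at 100 ug/mL (50 ug/mL to 200 ug/mL) in this assay, most likely reported as a limit rather than a number.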

Compound 3, half-maximal inhibitory concentration: > 100 ug/mL
Compound 3 ended at the assay's limit; the forecaster's own chance of this, stated with the estimate: 80%; the middle value sits exactly at the limit.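

In this assay no step can be read among compound 1, compound 2 and compound 3, since each returns only a limit of the assay and not a number: the limit of > 100 ug/mL in this assay, at which 3 of the 3 values shown sit.

The compounds shown leave open whether any of the changes on the carbonyl carbon shifts cytotoxicity, and at what concentration any of these three compounds would reach half-maximal inhibition.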